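The compounds below may be only part of what the source reports. "The series", "measured", "known", "first", "only" and "open" are said of these compounds alone.

Measured compounds:
Compound 1, `Cc1nc2c(c(-c3cc(F)c4c(c3C)CCCO4)c1[C@H](OC(C)(C)C)C(=O)O)CN(CCCc1ccc(F)cc1)CC2`, gives > 40000 nM in an ADME assay on MT2 cells (Homo sapiens) for cytotoxicity, read by XTT assay, with a stated time of 4 days; a higher number here means that more compound is tolerated, a lower number that less compound is tolerated.
Compound 2, `Cc1ccc(CCCN2CCc3nc(C)c([C@H](OC(C)(C)C)C(=O)O)c(-c4cc(F)c5c(c4C)CCCO5)c3C2)cc1F`, gives > 40000 nM in this assay.
Compound 3, `Cc1nc2c(c(-c3cc(F)c4c(c3C)CCCO4)c1[C@H](OC(C)(C)C)C(=O)O)CN(CCCc1ccccc1F)CC2`, gives > 40000 nM in this assay.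

Each of these three values is a limit of the assay and not a number, as the limit of > 40000 nM in this assay, at which 3 of the 3 values shown sit, shows. Compound 3 therefore stands only at a limit, and the two other values shown are limits as well. The change to compound 4, `Cc1ccc(CCCN2CCc3nc(C)c([C@H](OC(C)(C)C)C(=O)O)c(-c4cc(F)c5c(c4C)CCCO5)c3C2)cc1`, is 4-methylphenyl in place of 2-fluorophenyl on a saturated chain carbon, three bonds along the chain from an amine nitrogen in a ring. Among the measured compounds shown here, three measured steps bear on it, each swapping the aromatic group at the same place: a step that the two limits leave unreadable from compound 1 to compound 2, a step that the two limits leave unreadable from compound 1 to compound 3 and a step that the two limits leave unreadable from compound 2 to compound 3. None of them is readable in size, so they give neither a direction nor a size for the step to compound 4, and nothing beyond the scatter can be expected from them. Compound 4 is therefore expected to sit at the same limit, and the expected step of a number no higher from compound 3 to compound 4 (the limit leaves the size open) is estimated to be nothing beyond the scatter. Compound 4 is estimated at 40000 nM, with a range from 20000 nM to 80000 nM.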

Compound 4, half-maximal cytotoxic concentration: > 40000 nM
Compound 4: a limit, no number (the forecaster's own chance of this, stated with the estimate: 85%); the middle value lies on the limit itself.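

The steps to compound 4 from compound 1, compound 2 and compound 3 cannot be read, since all four compounds stand at one limit and not at a number: the limit of > 40000 nM in this assay, at which 4 of the 4 values shown sit. The compounds shown leave open what number each would give in this assay and whether swapping the aromatic group changes it at all.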